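One More Methyl on the Amine Nitrogen

The compounds below may be only part of what the source reports. "The series", "measured", "known", "first", "only" and "open" are said of these compounds alone.

In a functional assay on A549 cells (Homo sapiens) for antiproliferative activity, read by MTT assay, with a stated time of 48 h (a higher number here means a weaker inhibitor, a lower number a stronger inhibitor), compound 1 `C=C(c1ccc(OC)cc1NC(=O)CO)c1ccc(OC)c2c1C=CC(C)(C)O2` gives 70 nM with hydroxy on a saturated chain carbon bound to a carbonyl carbon. Compound 2 `C=C(c1ccc(OC)cc1NC(=O)CNC)c1ccc(OC)c2c1C=CC(C)(C)O2` has methylamino in that place and gives 320 nM as the higher, and so weaker, of the two numbers. That swap is a 4.6-fold higher number from compound 1 to compound 2 (0.66 log units; beyond the scatter) and counts as a modest step beyond the usual scatter.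

Compound 3 `C=C(c1ccc(OC)cc1NC(=O)CN(C)C)c1ccc(OC)c2c1C=CC(C)(C)O2` has methyl in place of hydrogen on the amine nitrogen, which turns methylamino into dimethylamino. The counted difference is methyl in place of hydrogen on an amine nitrogen and nothing else changes.

For the measured compounds named here, only one measured step bears on this, and it is an imperfect guide. The step to compound 2 at a 4.6-fold higher number from compound 1 to compound 2 (0.66 log units; beyond the scatter) replaced hydroxy with an amine, whereas here the amine stays and only gains a methyl. Going by the values given here, no measured pair shows what that methyl does, so no firm direction can be drawn. In this assay the expected change is a 1.1-fold higher number from compound 2 to compound 3 (0.04 log units; within the scatter) and it should stay within the scatter. For compound 3 the estimated value is 350 nM with an expected range from 110 nM to 1100 nM in this estimate.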

Compound 3, half-maximal inhibitory concentration: 550 nM
The estimate for compound 3 lay 1.6-fold (0.20 log units) below the measured number; the range from low to high includes it.
By their numbers in this assay, from the lowest: compound 1; then compounds 2 and 3 (each within the scatter of the next).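

In this assay, putting methyl in place of hydrogen on the amine nitrogen gives a 1.7-fold higher number from compound 2 to compound 3 (0.24 log units; within the scatter), so this single methyl does not clearly separate the methylamino and dimethylamino compounds. The comparison with the hydroxy compound is firmer: the swap to dimethylamino gives a 7.9-fold higher number from compound 1 to compound 3 (0.90 log units; beyond the scatter), which, like the swap to methylamino, lies beyond the scatter. Compound 1 is therefore the strongest of the three, and both amines tested at this place give clearly weaker numbers than hydroxy, while nothing measured here explains that gap.

The compounds shown leave open whether the plain amino group, with no methyl on the nitrogen, would stand closer to hydroxy or alongside the two methylated amines. Also open, as far as these compounds go, is how methoxy in place of hydroxy, or a ring amine such as pyrrolidine or morpholine in place of dimethylamino, would read in this assay, and so whether hydroxy itself or simply the absence of an amine nitrogen matters at this place.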